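The compounds below may be only part of what the source reports. "The series", "measured", "known", "first", "only" and "open" are said of these compounds alone.

Working notes on the series.

Compound 3 `CCOc1ncc(-c2nc(C(F)(F)F)sc2N2CCN(C(=O)Cn3ncc4cccnc43)[C@H](C)C2)cn1` gives 372 nM in an assay on blood for inhibition of C-X-C chemokine receptor type 3 (Homo sapiens), with a stated time of 30 min; on this read-out higher numbers stand for weaker inhibition and lower numbers for stronger inhibition. Among the three measured compounds it holds the second highest number: compound 2 `COc1ncc(-c2nc(C(F)(F)F)sc2N2CCN(C(=O)Cn3cnc4cccnc43)[C@H](C)C2)cn1` gives 158 nM, a lower number beyond the scatter, while compound 1 `C[C@@H]1CN(c2sc(C3COC3)nc2-c2nc3ccccc3[nH]2)CCN1C(=O)Cn1cnc2cccnc21` gives 1150 nM, a higher number also beyond the scatter. Compound 3 thus stands between the two.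

Compound 4 `CCOc1ncc(-c2nc(C(F)(F)F)sc2N2CCN(C(=O)Cn3cnc(C(F)(F)F)n3)[C@H](C)C2)cn1` is not yet measured. It differs from compound 3 in one place: a group of 9 heavy atoms (3 carbon, 3 nitrogen, 3 fluorine; one five-membered aromatic ring with 3 hetero atoms) in place of a group of 9 heavy atoms (6 carbon, 3 nitrogen; one five-membered aromatic ring with 2 hetero atoms, one six-membered aromatic ring with 1 hetero atom), on a saturated chain carbon bound to a carbonyl carbon. Going by the values given here, no measured pair shows this change, so there is no step to lean on. The amide-bound group is replaced wholesale, and the only measured variation at that position, between compound 2 and compound 3, is entangled with a change elsewhere, so what its two values show cannot be assigned to either change.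

The expectation for compound 4 is a modest step toward a higher number, estimated as a 1.7-fold higher number from compound 3 to compound 4 (0.24 log units; within the scatter), though a result within the scatter would not surprise. Compound 4 is estimated at 650 nM, with a range from 200 nM to 2000 nM.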

Compound 4, half-maximal inhibitory concentration: 524 nM
Beside the measured number, compound 4's estimate is 1.2-fold (0.09 log units) above it, and the stated range covers the measured number.
By their numbers in this assay, from the lowest: compound 2; then compounds 3 and 4 (each within the scatter of the next); then compound 1.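

Going by these compounds alone, the step at the amide-bound position, a 1.4-fold higher number from compound 3 to compound 4 (0.15 log units; within the scatter) in this assay, is the first reading there that involves no change elsewhere in the molecule. It shows that, on a saturated chain carbon bound to a carbonyl carbon, 3-(trifluoromethyl)-1H-1,2,4-triazol-1-yl, with its single five-membered aromatic ring, can stand in for the group with a five-membered and a six-membered aromatic ring without a separation beyond the scatter. No measurement bears on why the two groups read alike here.

It remains open whether the trifluoromethyl group itself matters, since the same triazole carrying a plain hydrogen or a nitrile in its place does not appear among these compounds. Also open, going by these compounds, is how an amine or a carboxylic acid would read on that chain carbon, and the gap between compound 2 and compound 3 still cannot be assigned to either of their differences.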